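Swapping methoxy for 1H-imidazol-1-yl: solubility outlook

The compounds below may be only part of what the source reports. "The series", "measured", "known", "first", "only" and "open" are said of these compounds alone.

Measured in a physicochemical assay for solubility, read by HPLC, with a stated time of 24 h; a higher number here means a more soluble compound, a lower number a less soluble compound:
Compound 1 `O=C1CSC(=O)N1C[C@H]1CN(c2ccc(-n3cc(-c4ccccn4)cn3)c(F)c2)C(=O)O1`: 26900 nM
Compound 2 `COC[C@H]1CN(c2ccc(-n3cc(-c4ccccn4)cn3)c(F)c2)C(=O)O1`: 36200 nM

Compound 2 holds the higher of the two numbers, yet a 1.3-fold higher number from compound 1 to compound 2 (0.13 log units; within the scatter) sits within the scatter. Compound 3 `O=C1O[C@@H](Cn2ccnc2)CN1c1ccc(-n2cc(-c3ccccn3)cn2)c(F)c1` differs from compound 2 by 1H-imidazol-1-yl in place of methoxy on a saturated chain carbon bound to a saturated ring carbon. Among the compounds with values here, the only step that bears on this change is the one from compound 1 to compound 2, which was small and within the scatter, and it concerns a different group leaving the same place. On that thin basis no step beyond the scatter is expected in this assay, so compound 3 is estimated at 45000 nM, with a range from 15000 nM to 130000 nM, an expected step of a 1.2-fold higher number from compound 2 to compound 3 (0.09 log units; within the scatter).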

Compound 3, solubility: 12300 nM
Estimate against measurement, compound 3: 3.7-fold (0.56 log units) above; measured number outside the range, below it.
By their numbers in this assay, from the lowest: compound 3; then compounds 1 and 2 (each within the scatter of the next).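

In this assay the place on a saturated chain carbon bound to a saturated ring carbon now shows a step beyond the scatter: 1H-imidazol-1-yl in place of methoxy gives a 2.9-fold lower number from compound 2 to compound 3 (0.47 log units; beyond the scatter) whereas the earlier change there stayed within it. 1H-imidazol-1-yl in place of 2,4-dioxo-1,3-thiazolidin-3-yl gives a 2.2-fold lower number from compound 1 to compound 3 (0.34 log units; beyond the scatter) in the same direction, which sets compound 3 apart from both other compounds. No evidence is available that accounts for this result.

The compounds shown leave open how an amine or a carboxylic acid at this place would read in this assay and whether another five-membered aromatic ring, such as 1H-1,2,3-triazol-1-yl, would fall close to compound 3.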